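The compounds below may be only part of what the source reports. "The series", "measured", "known", "first", "only" and "open" are said of these compounds alone.

Of the compounds shown here, three have been tested in a functional assay on PC-12 cells (Rattus norvegicus) for cytotoxicity, read by MTT assay, with a stated time of 24 h, tested at 1 uM; a higher number here means a stronger effect of the compound at the concentration tested, a lower number a weaker effect. Compound 1 `O=C(COc1ccc2ccccc2c1)N1CCN(C(c2ccc(Br)cc2)c2ccc(Br)cc2)CC1` gives 7.87%, compound 2 `COc1ccc(C(c2ccc(OC)cc2)N2CCN(C(=O)COc3ccccc3C)CC2)cc1` gives 3.75%, and compound 3 `COc1ccc(OCC(=O)N2CCN(C(c3ccc(C)cc3)c3ccc(C)cc3)CC2)cc1` gives 42.3%. Among these three numbers compound 1 stands second highest: its nearest neighbour is compound 2, whose number is lower by an amount that lies within the usual scatter, while the furthest is compound 3, whose number is higher by an amount that lies beyond it. Going by the values given here, no pair of measured compounds differs in a single place, so no measured step is available.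

Compound 4 `COc1ccc(OCC(=O)N2CCN(C(c3ccc(Br)cc3)c3ccc(Br)cc3)CC2)cc1` has not yet been measured. From compound 1 it differs by a single change: 4-methoxyphenyl in place of naphthalen-2-yl on an oxygen on a saturated carbon. Among the compounds with values here, since the only group entering here, the 4-methoxyphenoxy, is also found in compound 3, which gives the highest number of the three, a rise of moderate size is expected in this assay, though with wide uncertainty because compound 3 gives 42.3% with a different pair of aryl groups. The expected step of a number 10.1 percentage points higher from compound 1 to compound 4 (beyond the scatter) leads to an estimate for compound 4 of 18%, between 3% and 40%.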

Compound 4, a percentage reported as activity, at one concentration (the size of the read-out at that concentration, not a potency): 7.06%
Compound 4: middle estimate off by 10.9 percentage points, on the high side; measured number inside the range.
By their numbers in this assay, from the lowest: compounds 2, 4 and 1 (each within the scatter of the next); then compound 3.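

In this assay, 4-methoxyphenyl in place of naphthalen-2-yl on this oxygen gives a number 0.8 percentage points lower from compound 1 to compound 4 (within the scatter), so this change to the core of compound 1 leaves no readable effect. Two six-membered aromatic rings of carbon only give way to one, and a hydrogen-bond acceptor enters, yet the number stays within the scatter. On this core, then, the 4-methoxyphenoxy does not by itself bring a rise. No other measurement bears on why this is so.

The compounds shown leave open whether a cyclohexyl, a short alkyl chain or a chain ending in an amine at this oxygen would move the number. They also do not settle how much of the number of compound 3 (42.3%) belongs to its own pair of aryl groups.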